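The source may report more compounds than this note shows. Statements on the series, on what has been measured and on what is new or still open speak of the compounds shown alone.

Measured compounds:
- compound 1, `C[C@@H](O)[C@H]1C(=O)N2C3=C(S[C@@H]4CN[C@@H](C4)C(=O)Nc4cccc(c4)C(=O)OCOCOC3=O)[C@H](C)[C@H]12`: > 95%
- compound 2, `COC(=O)C1=C(S[C@@H]2CN[C@H](C(=O)Nc3cccc(C(=O)OC)c3)C2)[C@H](C)[C@@H]2[C@@H]([C@@H](C)O)C(=O)N12`: > 95%

In an ADME assay for metabolic stability, read by LC-MS, with a stated time of 3 h, at pH 6.5, tested at 50 uM (a lower number here means that less of the compound is left, a higher number that more of the compound is left), compound 1 gives > 95%, which is a limit of the assay and not a number. In this assay compound 2 gives > 95%, again a limit rather than a number. So compound 1 stands at the limit of > 95% in this assay, at which 2 of the 2 values shown sit, and nothing in the pair separates it from compound 2. Among the measured compounds shown here, no step between the two measured compounds is drawn, since they differ in more than one place, and the two values show only that both reach the limit.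

Compound 3, `CC(=O)O[C@H](C)[C@H]1C(=O)N2C3=C(S[C@@H]4CN[C@@H](C4)C(=O)Nc4cccc(c4)C(=O)OCOCOC3=O)[C@H](C)[C@H]12`, has not been measured in this assay. It differs from compound 1 by acetyl in place of hydrogen on an oxygen on a saturated carbon. For the measured compounds named here, with both measured values sitting at the limit, there is no measured step from which a direction could be read. For compound 3 the expected step is a number at least 15 percentage points lower from compound 1 to compound 3 (beyond the scatter), a drop that is likely to go beyond the scatter in the assay but is not certain to. For compound 3 the estimated value in this assay is 80%, with a range from 50% to 97%.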

Compound 3, percent of the compound remaining in the ADME assay: > 95%
Compound 3 gave a limit, no number (the forecaster's own chance of this, stated with the estimate: 30%); middle value at least 15 percentage points away from the limit.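

In a physicochemical assay for metabolic stability, read by LC-MS, in phosphate buffer, with a stated time of 3 h, at pH 7.4, tested at 50 uM (on this read-out higher numbers stand for a more stable compound and lower numbers for a less stable compound), compound 1 gives > 95%, which is a limit of the assay and not a number. In the physicochemical assay compound 3 gives > 95%, again a limit. Among the compounds shown here, with only limits for compound 1 and compound 3, no step between them can be read, either there or in the ADME assay. The compounds shown leave open whether acetyl in place of hydrogen on an oxygen on a saturated carbon changes the percent of the compound remaining at all.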